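Aryl urea series: trifluoromethoxy in place of dimethylamino

A few compounds are considered here, and "the series" means these few. Any claim that something is new, unique, unknown or untested is made for them only; others in the source may bear on it.

Of the compounds shown here, three have been measured in an ADME assay on HEK293 cells (Homo sapiens) for cytotoxicity, with a stated time of 72 h; a lower number here means that less compound is needed, a higher number that more compound is needed for the effect: compound 1 `Cc1cc(NC(=O)Nc2ccc(O)cc2)c2ccccc2n1`, compound 2 `COC(=O)c1ccc(NC(=O)Nc2cc(C)nc3ccccc23)cc1` and compound 3 `Cc1cc(NC(=O)Nc2ccc(N(C)C)cc2)c2ccccc2n1`. For compound 1 the read-out is only a limit, > 25000 nM. Compound 2 gives 15000 nM. For compound 3 the read-out is again only a limit, > 25000 nM, so compound 3 stands at the limit of > 25000 nM in this assay, at which 2 of the 3 values shown sit. The steps of an at least 1.6-fold lower number from compound 1 to compound 2 (0.22 log units; that floor lies within the scatter) and an at least 1.6-fold higher number from compound 2 to compound 3 (0.22 log units; that floor lies within the scatter) are each bounded on one side only, and the step that the two limits leave unreadable from compound 1 to compound 3. Compound 4 `Cc1cc(NC(=O)Nc2ccc(OC(F)(F)F)cc2)c2ccccc2n1` differs from compound 3 by trifluoromethoxy in place of dimethylamino on an aromatic carbon. Among the measured compounds shown here, no measured step involves trifluoromethoxy, and the two steps reaching compound 3 show it only at the limit, so no step beyond the scatter is expected in either direction. Compound 4 is expected to sit at or near that limit, a step of a number no higher from compound 3 to compound 4 (the limit leaves the size open). The estimate for compound 4 is 25000 nM, between 10000 nM and 60000 nM.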

Compound 4, half-maximal effective concentration: 14000 nM
For compound 4 the middle estimate is 1.8-fold (0.25 log units) above the measured one; the range from low to high includes it.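

Trifluoromethoxy, para to a large group, gives a second measured value in this assay rather than a limit, and it shows no separation from methoxycarbonyl at this position: a 1.1-fold lower number from compound 2 to compound 4 (0.03 log units; within the scatter). Against dimethylamino and hydroxy, the steps are bounded on one side only, an at least 1.7-fold lower number from compound 3 to compound 4 (0.25 log units; that floor lies within the scatter) and an at least 1.7-fold lower number from compound 1 to compound 4 (0.25 log units; that floor lies within the scatter), so their true size stays open: the limit of > 25000 nM in this assay, at which 2 of the 4 values shown sit.

Going by these compounds, whether a carboxylic acid or a primary amine at this position would give a measured value or stay at the limit remains open. So does whether other substituents would separate from these two measured groups beyond the scatter.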